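Chloro to fluoro swap carried across two cores

The compounds below may be only part of what the source reports. "The series", "measured", "known", "first", "only" and "open" are said of these compounds alone.

Measured in a functional assay on T47D cells (Homo sapiens) for inhibition, read by sulforhodamine B assay, with a stated time of 48 h; on this read-out higher numbers stand for weaker inhibition of growth and lower numbers for stronger inhibition of growth:
compound 1 `COC(=O)[C@@]1(C)CCC=C2[C@@H]1CC[C@@H](C)[C@]2(C)Cc1c[nH]c2ccc(Cl)cc12` gives 17000 nM
compound 2 `COC(=O)[C@@]1(C)CCC=C2[C@@H]1CC[C@@H](C)[C@]2(C)Cc1c[nH]c2ccc(F)cc12` gives 3900 nM
compound 3 `COC(=O)[C@@]1(C)CC[C@@H]2C3=C1CC[C@@H](C)[C@]3(C)C[C@@H]1c3cc(Cl)ccc3N[C@H]21` gives 28000 nM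

Compound 1 and compound 2 share one core and differ by fluoro in place of chloro on an aromatic carbon; that change gives a 4.4-fold lower number from compound 1 to compound 2 (0.64 log units; beyond the scatter). Compound 3 has the same atoms as compound 1 joined differently; the difference between the two cores is not broken down here. Compound 3 and compound 1 lie within the scatter of each other in this assay. Compound 4 `COC(=O)[C@@]1(C)CC[C@@H]2C3=C1CC[C@@H](C)[C@]3(C)C[C@@H]1c3cc(F)ccc3N[C@H]21` is not yet measured; it differs from compound 3 by fluoro in place of chloro on an aromatic carbon, the same kind of change as that between compound 1 and compound 2, the place now being part of a fused or bridged system of five rings rather than of two rings. The step is expected to be a 3.1-fold lower number from compound 3 to compound 4 (0.49 log units; beyond the scatter), resting on the change having given a 4.4-fold lower number from compound 1 to compound 2 (0.64 log units; beyond the scatter) on the other core. Compound 4 is estimated at 9000 nM, between 3000 nM and 28000 nM.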

Compound 4, concentration for 50% growth inhibition: 27000 nM
Compound 4: middle estimate off by 3.0-fold (0.48 log units), on the low side; low and high end bracket the measured number.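

In this assay, the step from fluoro in place of chloro on an aromatic carbon does not carry over between the two cores: the same change on two cores in this assay, a 4.4-fold lower number (0.64 log units; beyond the scatter) from compound 1 to compound 2 and a 1.0-fold lower number (0.02 log units; within the scatter) from compound 3 to compound 4, 4.2-fold (0.62 log units) apart, beyond the scatter of two such steps. On the core with the system of five rings, the same change gives a 1.0-fold lower number from compound 3 to compound 4 (0.02 log units; within the scatter), so the step seen on the other core is no guide here. This rests on a single pair per core in a single assay, and it does not show why the two cores differ or how any other group would behave on either one.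

Open, on these data alone, is whether a methoxy, trifluoromethyl or nitrile group at this place would shift the number on either core. Also open, as far as these compounds go, is what a carboxylic acid or an amide in place of the methyl ester would do.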